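This account rests on a few compounds, and the source may have more. Where it says the series, first, only, none or still open, it means among the compounds named here.

Measured so far:
- compound 1, `N=C(NS(=O)(=O)c1ccccc1Cl)N1CCN(c2cc3c(cc2F)c(=O)c(C(=O)O)cn3C2CC2)CC1`: 43 nM
- compound 2, `CCn1cc(C(=O)O)c(=O)c2cc(F)c(N3CCN(C(=N)NS(=O)(=O)c4ccccc4C(F)(F)F)CC3)cc21`: 43 nM
- compound 3, `CCn1cc(C(=O)O)c(=O)c2cc(F)c(N3CCN(C(=N)NS(=O)(=O)c4ccc(C(F)(F)F)cc4)CC3)cc21`: 43 nM

All three were read in a functional assay on HL-60 cells (Homo sapiens) for antiproliferative activity, read by MTT assay, with a stated time of 72 h; on this read-out lower numbers stand for stronger inhibition and higher numbers for weaker inhibition. Compound 3 stands level with compounds 1 and 2 at the digits shown; its nearest neighbour on the numbers is compound 1 and its furthest is compound 2, and both gaps lie within the scatter. Among the measured compounds shown here, the one measured step, no change at the digits printed from compound 2 to compound 3 (within the scatter), moves the trifluoromethyl group to a different place on the phenyl ring without any change beyond the scatter.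

Compound 4, `CCn1cc(C(=O)O)c(=O)c2cc(F)c(N3CCN(C(=N)NS(=O)(=O)c4ccccc4Cl)CC3)cc21`, has not yet been measured. It differs from compound 3 at the sulfonyl sulfur: 2-chlorophenyl in place of 4-(trifluoromethyl)phenyl on a sulfonyl sulfur. For the measured compounds named here, the step from compound 2 to compound 3 is the only measured step at this position and it was flat; compound 1, which carries the same 2-chlorophenyl on its sulfonyl sulfur with a different core, gives 43 nM, the same figure as compound 3. Nothing measured therefore points to a shift in this assay beyond the scatter. For compound 4 the expected step is no change at the digits printed from compound 3 to compound 4 (within the scatter), essentially none. Compound 4 is estimated at 43 nM, with a range from 20 nM to 90 nM.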

Compound 4, half-maximal inhibitory concentration: 43 nM
Compound 4: the middle estimate sits on the measured number at the digits printed; low and high end bracket the measured number.
By their numbers in this assay, from the lowest: compounds 1, 2, 3 and 4 (each within the scatter of the next).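

In this assay, the sulfonyl substituent now tolerates a change of group as well as a move of the trifluoromethyl: the swap of 4-(trifluoromethyl)phenyl for 2-chlorophenyl gives no change at the digits printed from compound 3 to compound 4 (within the scatter), and chloro in place of trifluoromethyl on an aromatic carbon gives no change at the digits printed from compound 2 to compound 4 (within the scatter). With 2-chlorophenyl held constant, compound 4 also gives the first single-change read on the aromatic nitrogen, where ethyl in place of cyclopropyl gives no change at the digits printed from compound 1 to compound 4 (within the scatter). No measurement available here accounts for these flat steps.

Still open, going by these compounds, is whether a methoxy or amino group in place of chloro on an aromatic carbon would shift the read-out. The same question applies to a propyl or longer chain in place of ethyl on the aromatic nitrogen.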